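Adding a Second Chloro Next to the First

A few compounds are considered here, and "the series" means these few. Any claim that something is new, unique, unknown or untested is made for them only; others in the source may bear on it.

Compound 1, `CCOC(=O)c1c(-c2cccc(Cl)c2)[nH]c2cccc(OC)c2c1=O`, gives > 100000 nM in a physicochemical assay for solubility, in phosphate buffer, at pH 7.4 (on this read-out higher numbers stand for higher solubility and lower numbers for lower solubility), which is a limit of the assay.
Compound 2, `CCOC(=O)c1c(-c2cccc([N+](=O)[O-])c2)[nH]c2cccc(OC)c2c1=O`, gives 49000 nM.
Compound 3, `CCOC(=O)c1c(-c2ccc(Cl)cc2)[nH]c2cccc(OC)c2c1=O`, gives > 100000 nM, again a limit.

As far as these compounds go, compound 3 thus stands at the limit of > 100000 nM in this assay, at which 2 of the 3 values shown sit, so its true value is unknown. Compound 4, `CCOC(=O)c1c(-c2ccc(Cl)c(Cl)c2)[nH]c2cccc(OC)c2c1=O`, differs by chloro in place of hydrogen on an aromatic carbon. No measured step swaps hydrogen for chloro; the only steps shown, an at least 2.0-fold lower number from compound 1 to compound 2 (0.30 log units; that floor lies within the scatter) and an at least 2.0-fold higher number from compound 2 to compound 3 (0.30 log units; that floor lies within the scatter), concern nitro versus chloro, while a step that the two limits leave unreadable from compound 1 to compound 3 stays unreadable. There is no measured basis for a clear direction, so compound 4 is expected to land near the limit again, with a small expected step of an at least 1.2-fold lower number from compound 3 to compound 4 (0.09 log units; that floor lies within the scatter). The estimate for compound 4 is 80000 nM, ranging from 25000 nM to 200000 nM.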

Compound 4, solubility: 39000 nM
Compound 4: middle estimate off by 2.1-fold (0.31 log units), on the high side, within the range that was stated.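

In this assay, going by these compounds alone, going from 4-chlorophenyl to 3,4-dichlorophenyl gives an at least 2.5-fold lower number from compound 3 to compound 4 (0.40 log units; beyond the scatter), the first hydrogen-to-chloro swap on this aromatic ring with a readable step. Adding the other chloro to the 3-chlorophenyl compound points the same way, with an at least 2.5-fold lower number from compound 1 to compound 4 (0.40 log units; beyond the scatter), so the drop appears from either single-chloro compound. Against the nitro compound, there is only a 1.3-fold lower number from compound 2 to compound 4 (0.10 log units; within the scatter), so 3,4-dichlorophenyl and 3-nitrophenyl cannot be told apart here.

As far as these compounds go, the true size of the two chloro steps stays open, as each starts from a limit: the limit of > 100000 nM in this assay, at which 2 of the 4 values shown sit. Also open is how an amine or a carboxylic acid would read in place of the added chloro.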